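A few compounds are considered here, and "the series" means these few. Any claim that something is new, unique, unknown or untested is made for them only; others in the source may bear on it.

Measured compounds in a functional assay on the whole organism for antagonist activity, with Mus musculus as the target; a higher number here means that more compound is needed for the effect, a lower number that less compound is needed:
- compound 1 `COc1cc(N)c(Cl)cc1NC(=O)C1CCN(Cc2ccc(F)cc2)CC1`: 0.6 mg/kg
- compound 2 `COc1cc(N)c(Cl)cc1NC(=O)C1CCN(CC2CCCCCC2)CC1`: > 10 mg/kg, a limit of the assay, not a number
- compound 3 `COc1cc(N)c(Cl)cc1NC(=O)C1CCN(Cc2ccc([N+](=O)[O-])cc2)CC1`: > 4 mg/kg, a limit of the assay, not a number

Compound 3 therefore stands at a limit in this assay with no number of its own. One further value in the set is likewise only a limit (the limit of > 10 mg/kg in this assay, at which 1 of the 3 values shown sits).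

The change to compound 4 `CCCCCCN1CCC(C(=O)Nc2cc(Cl)c(N)cc2OC)CC1` is pentyl in place of 4-nitrophenyl on a saturated chain carbon bound to an amine nitrogen in a ring. Among the measured compounds shown here, two measured steps bear on it. Exchanging an aromatic group for a saturated one gave an at least 16-fold higher number from compound 1 to compound 2 (1.22 log units; beyond the scatter), a large rise. The step that the two limits leave unreadable from compound 2 to compound 3 stays unreadable between the two limits, and an at least 6.6-fold higher number from compound 1 to compound 3 (0.82 log units; beyond the scatter) was already a rise. A pentyl at the same place is thus expected to leave compound 4 at or past the limit of compound 3, with a step that the limit leaves unreadable from compound 3 to compound 4 as the expected step. Compound 4 is estimated at 15 mg/kg, between 4 mg/kg and 40 mg/kg.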

Compound 4, dose for half-maximal effect: > 10 mg/kg
Compound 4: a limit, no number (the forecaster's own chance of this, stated with the estimate: 70%); the middle value does not contradict the limit.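

Replacing 4-fluorophenyl with pentyl on a saturated chain carbon bound to an amine nitrogen in a ring gives, in this assay, an at least 16-fold higher number from compound 1 to compound 4 (1.22 log units; beyond the scatter). An open chain with no ring thus joins the ring-bearing cycloheptyl of compound 2, leaving compound 1 as the only compound shown with a number of its own. The value of compound 4 is a limit, so its steps to compound 2 and compound 3 cannot be read: the limit of > 10 mg/kg in this assay, at which 2 of the 4 values shown sit.

On these data alone, how far compound 2, compound 3 and compound 4 lie past their limits remains open. Also open, as far as these compounds go, is whether unsubstituted phenyl or 4-chlorophenyl in place of 4-fluorophenyl would give a measurable number.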